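Chlorinated isothiazolone cores and a methoxycarbonyl chain

This account rests on a few compounds, and the source may have more. Where it says the series, first, only, none or still open, it means among the compounds named here.

The series rests on a small set of isothiazolone compounds tested in an assay on isolated protein for inhibition of histone acetyltransferase KAT2B (Homo sapiens), read by fluorescence, with a stated time of 15 min; a lower number here means a stronger inhibitor, a higher number a weaker inhibitor. Compound 1, `CCn1sc(Cl)cc1=O`, gives 3000 nM in this assay. Compound 2, `COC(=O)CCn1sc(Cl)cc1=O`, carries the change methoxycarbonyl in place of hydrogen on a saturated chain carbon, two bonds along the chain from an aromatic nitrogen and gives 1800 nM; the step of a 1.7-fold lower number from compound 1 to compound 2 (0.22 log units; within the scatter) describes that move. Compound 3, `CCn1sc(Cl)c(Cl)c1=O`, differs from compound 1 by chloro in place of hydrogen on an aromatic carbon, and in this assay compound 3 gives 2400 nM, so that the step of a 1.3-fold lower number from compound 1 to compound 3 (0.10 log units; within the scatter) also stays inside the usual spread of repeated measurements. Among the three measured compounds, therefore, no value can be ordered against another with confidence.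

Compound 4, `COC(=O)CCn1sc(Cl)c(Cl)c1=O`, has not been measured. It relates to compound 3 in the same way that compound 2 relates to compound 1: the change is methoxycarbonyl in place of hydrogen on a saturated chain carbon, two bonds along the chain from an aromatic nitrogen, on a place that is word for word the same as in the earlier pair, so the same change is made a second time, here on the core of compound 3 rather than the core of compound 1.

For the measured compounds named here, the only guide to what to expect is the single earlier occurrence of this change, a 1.7-fold lower number from compound 1 to compound 2 (0.22 log units; within the scatter), which is itself within the scatter. Because of that step, compound 4 is expected to sit at a step of about a 1.6-fold lower number from compound 3 to compound 4 (0.20 log units; within the scatter) from compound 3. In this assay compound 4 is estimated at 1500 nM, with a plausible range from 700 nM to 3200 nM, given how little the earlier step moved.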

Compound 4, half-maximal inhibitory concentration: 2600 nM
Estimate against measurement, compound 4: 1.7-fold (0.24 log units) below, and the stated range covers the measured number.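

In this assay, the methoxycarbonyl change made on the core of compound 3 gives a 1.1-fold higher number from compound 3 to compound 4 (0.03 log units; within the scatter), and its two occurrences do not differ measurably: the same change on two cores in this assay, a 1.7-fold lower number (0.22 log units; within the scatter) from compound 1 to compound 2 and a 1.1-fold higher number (0.03 log units; within the scatter) from compound 3 to compound 4, 1.8-fold (0.26 log units) apart, within the scatter of two such steps. The chloro change made on the core of compound 2 gives a 1.4-fold higher number from compound 2 to compound 4 (0.16 log units; within the scatter), and it likewise agrees with its earlier occurrence: the same change on two cores in this assay, a 1.3-fold lower number (0.10 log units; within the scatter) from compound 1 to compound 3 and a 1.4-fold higher number (0.16 log units; within the scatter) from compound 2 to compound 4, 1.8-fold (0.26 log units) apart, within the scatter of two such steps. Both changes therefore carry from one core to the other without a detectable difference, but all four steps lie within the scatter, so this shows neither that either change has a real effect on the number nor that the two changes add up or interfere.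

The compounds shown leave open whether a carboxylic acid or an amide in place of the methoxycarbonyl, or a longer chain, would give a step beyond the scatter. They also leave open what a fluoro or a methyl in place of chloro would do on the shared core.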